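The compounds below may be only part of what the source reports. "The series", "measured", "known", "first", "only" and "open" are said of these compounds alone.

Three close relatives of one shared core have been tested in an assay on membranes from HeLa cells for displacement of a labelled ligand from adenosine receptor A3 (Homo sapiens), read by scintillation counting, with a stated time of 180 min, tested at 1 uM; a lower number here means less inhibition, a higher number more inhibition at the concentration tested (going by the name of the read-out). Compound 1 `COC(=O)C1=C(C)NC(=O)NC1c1ccoc1` gives 2%, compound 2 `CCCC(=O)C1=C(C)NC(=O)NC1c1ccoc1` gives 2%, and compound 3 `CCNC(=O)C1=C(C)NC(=O)NC1c1ccoc1` gives 1%. Compound 3 stands level with its two neighbours: the steps of a number 1 percentage points lower from compound 1 to compound 3 (within the scatter) and a number 1 percentage points lower from compound 2 to compound 3 (within the scatter) both sit inside the scatter, as does no change at the digits printed from compound 1 to compound 2 (within the scatter). Compound 4 `CCC(C)OC(=O)C1=C(C)NC(=O)NC1c1ccoc1` differs from compound 3 at the same carbonyl carbon that has been varied before: sec-butoxy in place of ethylamino on a carbonyl carbon. The three measured swaps at this carbon all left the read-out flat, so a flat step is expected here too, a number 1 percentage points higher from compound 3 to compound 4 (within the scatter). For compound 4 the estimate is 2%, with a range from -5% to 10%.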

Compound 4, a percentage reported as inhibition, at one concentration (the size of the read-out at that concentration, not a potency): 11%
For compound 4 the middle estimate is 9 percentage points below the measured one; the measured number lies above the stated range.
By their numbers in this assay, from the lowest: compounds 3, 1, 2 and 4 (each within the scatter of the next).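

In this assay sec-butoxy at this carbonyl carbon stays within the scatter of all three earlier groups, with a number 10 percentage points higher from compound 3 to compound 4 (within the scatter) and a number 9 percentage points higher from compound 2 to compound 4 (within the scatter) and a number 9 percentage points higher from compound 1 to compound 4 (within the scatter). These are the largest steps seen at this position so far, yet none clears the scatter, so no swap here has been shown to move the read-out. Nothing measured accounts for these numbers. On these data alone, whether a longer alkoxy chain or a carboxylic acid at this carbonyl carbon would move the read-out beyond the scatter stays open.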